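Oxazoline to pyrroline swap on the biphenyl ether core

This account rests on a few compounds, and the source may have more. Where it says the series, first, only, none or still open, it means among the compounds named here.

Compound 1 `CC(Oc1ccccc1-c1ccccc1)C1=NCCO1` carries a five-membered ring with two hetero atoms on the saturated chain carbon that links to the aromatic oxygen. Within the data shown here, in an assay on CHO cells for displacement of a labelled ligand from Alpha-2B adrenergic receptor (Homo sapiens) (on this read-out lower numbers stand for stronger inhibition and higher numbers for weaker inhibition), compound 1 gives 10000 nM, the highest of the two numbers measured so far. Among the measured compounds shown here, the only other measured member, compound 2 `CC(Oc1ccccc1-c1ccccc1[N+](=O)[O-])C1=NCCN1`, gives 1550 nM in this assay; it differs from compound 1 in more than one place, so the two values are compared only as they stand, and the gap between them lies beyond the scatter.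

Compound 3 `CC(Oc1ccccc1-c1ccccc1)C1=NCCC1` is the untested analogue of compound 1. The change is a group of 5 heavy atoms (4 carbon, 1 nitrogen; one five-membered non-aromatic ring with 1 hetero atom) in place of a group of 5 heavy atoms (3 carbon, 1 nitrogen, 1 oxygen; one five-membered non-aromatic ring with 2 hetero atoms), on a saturated chain carbon bound to an oxygen on an aromatic ring and a saturated chain carbon. For the measured compounds named here, no measured pair isolates this exchange, so the direction is open. The expectation for the step from compound 1 to compound 3 is a 2.0-fold lower number from compound 1 to compound 3 (0.30 log units; within the scatter), a modest move toward a lower number, with wide uncertainty because compound 1 already sits at 10000 nM, the highest number measured here. Compound 3 is accordingly estimated at 5000 nM in this assay, within a range of 1000 nM to 20000 nM.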

Compound 3, inhibition constant: 10000 nM
Compound 3: the middle estimate sits 2.0-fold (0.30 log units) below what was measured; the range from low to high includes it.
By their numbers in this assay, from the lowest: compound 2; then compounds 1 and 3 (each within the scatter of the next).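

On the saturated chain carbon bound to an oxygen on an aromatic ring and a saturated chain carbon, putting the five-membered non-aromatic ring with 1 hetero atom in place of the one with 2 hetero atoms gives, in this assay, no change at the digits printed from compound 1 to compound 3 (within the scatter). Among these compounds, this is the first pair that differs in one place, and it shows that at this position the count can go from 2 hydrogen-bond acceptors to 1 hydrogen-bond acceptor, with the ring size and the double bond outside aromatic rings kept, without a move beyond the scatter. No supporting measurement bears on why the number holds across this exchange.

Compound 2 at 1550 nM differs from compound 1 in more than one place, so nothing can yet be assigned to its ring or to its nitro group alone. As far as these compounds go, whether a primary amine, a carboxylic acid or a longer chain on this carbon would give a number outside the scatter of compound 1 and compound 3 remains open.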